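The source may hold more compounds than are shown below. What is called first, only, known or untested is meant among the compounds shown, and "the series" means these compounds.

In an assay on cells for inhibition of ileal sodium/bile acid cotransporter (Homo sapiens) (a higher number here means a weaker inhibitor, a lower number a stronger inhibitor), compound 3 `CCCC[C@]1(CC)CS(=O)(=O)c2ccc(SC)cc2[C@@H](c2ccc(F)cc2)[C@H]1O` gives 19 nM, the second highest of the three numbers recorded. Compound 2 `CCCC[C@]1(CC)CS(=O)(=O)c2ccc(N(C)C)cc2[C@@H](c2ccccc2)[C@H]1O`, with 5 nM, sits nearest to it, and the gap lies beyond the scatter. Compound 1 `CCCC[C@]1(CC)CS(=O)(=O)c2ccc(-c3ccccc3)cc2[C@@H](c2cccc(OC)c2)[C@H]1O`, with 180 nM, is the furthest away, again beyond the scatter. Compound 4 `CCCC[C@]1(CC)CS(=O)(=O)c2ccc(C3CCNC3)cc2[C@@H](c2ccc(F)cc2)[C@H]1O` arises from compound 3 by one change: pyrrolidin-3-yl in place of methylsulfanyl on an aromatic carbon. Going by the values given here, no measured pair shows this exact exchange, so the step can only be estimated. Among the compounds with values here, because compound 2, the one compound bearing a nitrogen-containing substituent on the core, gives 5 nM, the expectation is a moderate shift toward stronger inhibition, a 2.4-fold lower number from compound 3 to compound 4 (0.38 log units; beyond the scatter), beyond the scatter. Compound 4 is therefore estimated at 8 nM in this assay, within a range from 3 nM to 25 nM.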

Compound 4, half-maximal inhibitory concentration: 59 nM
Compound 4: the middle estimate sits 7.4-fold (0.87 log units) below what was measured, and the stated range ends below it.
By their numbers in this assay, from the lowest: compound 2; then compound 3; then compound 4; then compound 1.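

Pyrrolidin-3-yl in place of methylsulfanyl on this aromatic carbon weakens inhibition in this assay, with a 3.1-fold higher number from compound 3 to compound 4 (0.49 log units; beyond the scatter). Going by these compounds alone, this is the first direct reading of a change at this position, and it shows that the position is sensitive to the group it carries, while a five-membered non-aromatic ring with a hetero atom still leaves compound 4 an inhibitor. Nothing available explains the step. The compounds shown leave open whether the ring or its nitrogen accounts for the step. A cyclopentyl group on this carbon, or an acetyl group on the ring nitrogen, would separate the two.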